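Change at the carbonyl carbon: outlook for compound 3

The compounds below may be only part of what the source reports. "The series", "measured", "known", "first", "only" and "open" are said of these compounds alone.

Measured compounds:
compound 1 `COc1ccc(-c2cc3ccccc3nc2/C=C/C(=O)c2c(OC)cccc2OC)cc1`: 3830 nM
compound 2 `COc1ccc(-c2cc3ccccc3nc2/C=C/C(=O)c2ccc(OC)c(OC)c2)cc1`: 3260 nM

In a functional assay on SK-BR-3 cells (Homo sapiens) for antiproliferative activity, read by XTT assay, with a stated time of 72 h (a higher number here means a weaker inhibitor, a lower number a stronger inhibitor), compound 1 gives 3830 nM and compound 2 gives 3260 nM. Going by the values given here, compound 2 holds the lower of the two numbers, but its only neighbour is compound 1 and a 1.2-fold lower number from compound 1 to compound 2 (0.07 log units; within the scatter) lies within the scatter, so no order can be read between the two. Compound 3 `COc1ccc(-c2cc3ccccc3nc2/C=C/C(=O)c2ccc(N)cc2)cc1` has not been measured; it differs from compound 2 as 4-aminophenyl in place of 3,4-dimethoxyphenyl on a carbonyl carbon. Among the compounds with values here, the one step that bears on this site is a 1.2-fold lower number from compound 1 to compound 2 (0.07 log units; within the scatter), an exchange of one aryl group for another at the same carbonyl carbon that left the number essentially unchanged. On that basis no step beyond the scatter is expected in this assay for compound 3 in either direction, though the groups exchanged here differ more widely than in that step, so a broader range is allowed. Compound 3 is expected to give 3000 nM (range 900 nM to 10000 nM), a step of a 1.1-fold lower number from compound 2 to compound 3 (0.04 log units; within the scatter) that is expected to stay within the scatter.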

Compound 3, half-maximal inhibitory concentration: 8560 nM
Compound 3: the middle estimate sits 2.9-fold (0.46 log units) below what was measured, within the range that was stated.
By their numbers in this assay, from the lowest: compounds 2 and 1 (each within the scatter of the next); then compound 3.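

In this assay, the carbonyl carbon is not indifferent to the aryl group it carries: a 2.6-fold higher number from compound 2 to compound 3 (0.42 log units; beyond the scatter), with 4-aminophenyl in place of 3,4-dimethoxyphenyl, and a 2.2-fold higher number from compound 1 to compound 3 (0.35 log units; beyond the scatter), with 4-aminophenyl in place of 2,6-dimethoxyphenyl. Going by these compounds alone, the two dimethoxyphenyl compounds stood within the scatter of each other, so these are the first steps at this site to go beyond the scatter; both are modest and both run towards a weaker inhibitor. No measurement at hand accounts for this shift.

On these data alone, whether the higher number goes with the entry of the amine or the loss of the methoxy groups stays open. A 4-methoxyphenyl or an unsubstituted phenyl group on the same carbonyl carbon would separate the two readings.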